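Chain branching and agonist potency at the ecdysone receptor

This account rests on a few compounds, and the source may have more. Where it says the series, first, only, none or still open, it means among the compounds named here.

Measured so far, in an assay on cells for agonist activity at ecdysone receptor (Bombyx mori), read by a luciferase reporter, with a stated time of 24 h; a lower number here means that less compound is needed, a higher number that more compound is needed for the effect:
compound 1 `CCCCCC(=O)N(NC(=O)c1ccc(CC)cc1)C(C)(C)C` gives 2820 nM;
compound 2 `CCc1ccc(C(=O)NN(C(=O)CCC(C)C)C(C)(C)C)cc1` gives 832 nM;
compound 3 `CCCCN(NC(=O)c1ccccc1)C(=O)c1ccccc1` gives 7080 nM.

Among the compounds with values here, the one counted step is isopropyl in place of propyl on a saturated chain carbon, two bonds along the chain from a carbonyl carbon, which gives a 3.4-fold lower number from compound 1 to compound 2 (0.53 log units; beyond the scatter). Compound 3 carries a different core, and the difference between the two cores is not broken down here; its value is the highest of the three numbers. Compound 4 `CC(C)CN(NC(=O)c1ccccc1)C(=O)c1ccccc1` is not yet measured. It differs from compound 3 by isopropyl in place of propyl on a saturated chain carbon bound to an amide-type nitrogen, the same kind of change as between compound 1 and compound 2, but at a different place. Because the earlier step of a 3.4-fold lower number from compound 1 to compound 2 (0.53 log units; beyond the scatter) was modest and sat at another place, a smaller shift is expected here: a 2.0-fold lower number from compound 3 to compound 4 (0.31 log units; beyond the scatter). For compound 4 the estimate is 3500 nM, between 1200 nM and 10000 nM.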

Compound 4, half-maximal effective concentration: 2880 nM
Beside the measured number, compound 4's estimate is 1.2-fold (0.08 log units) above it; the measured number falls inside the stated range.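

In this assay, isopropyl in place of propyl on the second core gives a 2.5-fold lower number from compound 3 to compound 4 (0.39 log units; beyond the scatter). Set beside the step on the first core, the two sizes agree: the same change on two cores in this assay, a 3.4-fold lower number (0.53 log units; beyond the scatter) from compound 1 to compound 2 and a 2.5-fold lower number (0.39 log units; beyond the scatter) from compound 3 to compound 4, 1.4-fold (0.14 log units) apart, within the scatter of two such steps. This shows that the change carried over between these two pairs in direction and in size, but it sits at a different place on each core, and two pairs do not show that the step is independent of place or that it would hold on a further core.

On these data alone, whether a longer branched chain or a cyclopropyl group on a saturated chain carbon bound to an amide-type nitrogen continues the step remains open. Also open, as far as these compounds go, is how the change behaves at both places on one core.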